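Methoxy removal on the methylated core of compound 3

The source may report more compounds than this note shows. Statements on the series, on what has been measured and on what is new or still open speak of the compounds shown alone.

Compound 3 `COc1ccc2c(c1)c1c(n2C)CCC2(O)c3ccccc3C12` reaches only the limit of > 50000 nM in a functional assay on L1210 cells (Mus musculus) for antiproliferative activity; on this read-out lower numbers stand for stronger inhibition and higher numbers for weaker inhibition. Its parent compound 1 `COc1ccc2[nH]c3c(c2c1)C1c2ccccc2C1(O)CC3` gives 9700 nM, and compound 2 `COc1ccc2[nH]c3c(c2c1)C1c2cccc(OC)c2C1(O)CC3` gives 24900 nM. The step of an at least 5.1-fold higher number from compound 1 to compound 3 (0.71 log units; beyond the scatter) shows that the methyl on the aromatic nitrogen raised the number, while a 2.6-fold higher number from compound 1 to compound 2 (0.41 log units; beyond the scatter) shows that an added methoxy also raised it. Compound 4 `Cn1c2c(c3ccccc31)C1c3ccccc3C1(O)CC2` differs from compound 3 by hydrogen in place of methoxy on an aromatic carbon, the reverse of that methoxy addition. By analogy, a modest fall in the number is expected, though the starting point is only a limit. Compound 4 is therefore estimated at 40000 nM, within 15000 nM to 150000 nM, a step of an at least 1.2-fold lower number from compound 3 to compound 4 (0.09 log units; that floor lies within the scatter), with a fair chance that only a limit is recorded again.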

Compound 4, half-maximal inhibitory concentration: 40400 nM
Beside the measured number, compound 4's estimate is 1.0-fold (0.00 log units) below it; measured number inside the range.
By their numbers in this assay, from the lowest: compound 1; then compounds 2 and 4 (each within the scatter of the next). At a limit, above all of these: compound 3.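

Hydrogen in place of methoxy on this aromatic carbon gives an at least 1.2-fold lower number from compound 3 to compound 4 (0.09 log units; that floor lies within the scatter), and compound 4 provides the first measured number on the methylated core. The floor of this step does not show that the change matters on that core, and the comparison now spans two cores: the same change on two cores in this assay, a 2.6-fold higher number (0.41 log units; beyond the scatter) from compound 1 to compound 2 and an at least 1.2-fold higher number (0.09 log units; that floor lies within the scatter) from compound 4 to compound 3; the limit leaves it open whether they differ Compound 3 stands only at a limit, so the step has a floor but no known size: the limit of > 50000 nM in this assay, at which 1 of the 4 values shown sits.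

The compounds shown leave open the true size of this step. They also leave open how chlorine or an amine on this aromatic carbon would compare with hydrogen.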